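Methoxy for hydrogen: carrying one step across cores

The compounds below may be only part of what the source reports. "The series", "measured", "known", "first", "only" and "open" are said of these compounds alone.

Measured compounds and their values in a functional assay on A549 cells (Homo sapiens) for cytotoxicity, read by WST assay, with a stated time of 48 h; a higher number here means a weaker inhibitor, a lower number a stronger inhibitor:
compound 1, `COc1ccc2[nH]cc(/C=C(\C#N)C(=O)c3c[nH]c4ccccc34)c2c1`, gives 13700 nM
compound 2, `COc1ccc2[nH]cc(/C=C(\C#N)C(=O)c3c[nH]c4ccc(OC)cc34)c2c1`, gives 24500 nM
compound 3, `N#C/C(=C\c1c[nH]c2cc(F)ccc12)C(=O)c1c[nH]c2ccccc12`, gives 22700 nM

Compound 1 and compound 2 differ in one place, (methoxy in place of hydrogen on an aromatic carbon), and the step of a 1.8-fold higher number from compound 1 to compound 2 (0.25 log units; within the scatter). Compound 3 sits near compound 2 and compound 1; the difference between the core of compound 3 and the core of compound 1 is not broken down here, and all three values lie within the usual scatter of one another, so no order among them is claimed.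

Compound 4, `COc1ccc2[nH]cc(C(=O)/C(C#N)=C/c3c[nH]c4cc(F)ccc34)c2c1`, is not yet measured. It differs from compound 3 by methoxy in place of hydrogen on an aromatic carbon, the same change as from compound 1 to compound 2, at a place described in the same words. Because a 1.8-fold higher number from compound 1 to compound 2 (0.25 log units; within the scatter) stayed within the scatter, the step from compound 3 to compound 4 is expected to be small as well, estimated as a 1.4-fold higher number from compound 3 to compound 4 (0.15 log units; within the scatter). On that basis compound 4 is expected to give about 32000 nM in this assay, with a likely range from 15000 nM to 70000 nM. This estimate rests on a single earlier step and on the value of compound 3, so it is tentative.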

Compound 4, half-maximal inhibitory concentration: > 50000 nM
Compound 4: only a limit was reported (the forecaster's own chance of this, stated with the estimate: 15%); at least 1.5-fold (0.19 log units) between middle value and limit.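

In this assay compound 4 gives > 50000 nM, which is a limit and not a number. Methoxy in place of hydrogen on an aromatic carbon gives an at least 2.2-fold higher number from compound 3 to compound 4 (0.34 log units; beyond the scatter), so on the core of compound 3 the step lies beyond the scatter, and the step on the core of compound 1 goes toward a higher number as well but stays within the scatter. This points to the same direction on both cores, but it does not show that the size of the step carries from one core to the other: the same change on two cores in this assay, a 1.8-fold higher number (0.25 log units; within the scatter) from compound 1 to compound 2 and an at least 2.2-fold higher number (0.34 log units; beyond the scatter) from compound 3 to compound 4; the limit leaves it open whether they differ.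

The compounds shown leave open how the number responds when other groups stand on that aromatic carbon, such as an amine, a carboxylic acid or a longer alkoxy chain. Among the compounds shown here, also open is whether methoxy in place of hydrogen on a further core would give a step in the same direction, since only two cores carry this change here.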